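Cyclic amine variants at the chain carbon of the shared core

This account rests on a few compounds, and the source may have more. Where it says the series, first, only, none or still open, it means among the compounds named here.

compound 1 `CCCN(Cc1c(C(F)(F)F)nc2n1CCCN2c1c(C)cc(C)cc1C)CC1CCC1`: 21 nM in an in vitro assay on IMR-32 cells for displacement of a labelled ligand from corticotropin-releasing factor receptor 1 (Homo sapiens); a higher number here means a weaker inhibitor, a lower number a stronger inhibitor
compound 2 `CCN(Cc1c(C(F)(F)F)nc2n1CCCN2c1c(C)cc(C)cc1C)CC1CC1`: 31 nM in this assay
compound 3 `Cc1cc(C)c(N2CCCn3c2nc(C(F)(F)F)c3CN2CCCCC2)c(C)c1`: 245 nM in this assay

Compound 3 gives the highest number of the three in this assay: the step is a 12-fold higher number from compound 1 to compound 3 (1.07 log units; beyond the scatter) and a 7.9-fold higher number from compound 2 to compound 3 (0.90 log units; beyond the scatter). Compound 4 `Cc1cc(C)c(N2CCCn3c2nc(C(F)(F)F)c3CN2CC=CCC2)c(C)c1` differs from compound 3 by a group of 6 heavy atoms (5 carbon, 1 nitrogen; one six-membered non-aromatic ring with 1 hetero atom) in place of a group of 6 heavy atoms (5 carbon, 1 nitrogen; one six-membered non-aromatic ring with 1 hetero atom), on a saturated chain carbon bound to an aromatic carbon. Among the measured compounds shown here, no measured step bears directly on this change: both steps into compound 3 concern piperidin-1-yl in place of another amine, and none alters a six-membered ring by a double bond alone. With no guide among the measured compounds, the expected step is a 1.2-fold lower number from compound 3 to compound 4 (0.09 log units; within the scatter), not beyond the scatter. Compound 4 is therefore estimated at 200 nM in this assay, with a range of 70 nM to 600 nM.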

Compound 4, inhibition constant: 364 nM
Compound 4: the middle estimate sits 1.8-fold (0.26 log units) below what was measured, within the range that was stated.
By their numbers in this assay, from the lowest: compounds 1 and 2 (each within the scatter of the next); then compounds 3 and 4 (each within the scatter of the next).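

A double bond in the six-membered ring on the saturated chain carbon gives no readable change from piperidin-1-yl in this assay (a 1.5-fold higher number from compound 3 to compound 4 (0.17 log units; within the scatter)). This second cyclic amine also stays clearly apart from the open-chain amines (a 12-fold higher number from compound 2 to compound 4 (1.07 log units; beyond the scatter); a 17-fold higher number from compound 1 to compound 4 (1.24 log units; beyond the scatter)), so the gap seen with compound 3 is not confined to the saturated ring. No evidence is available to explain these numbers.

As far as these compounds go, whether pyrrolidine or azepane, with a smaller or larger ring, would narrow this gap remains open. So does the outcome for morpholine, with an oxygen in the six-membered ring.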